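This account rests on a few compounds, and the source may have more. Where it says the series, first, only, none or still open, it means among the compounds named here.

Among the compounds with values here, in a functional assay on KG-1 cells (Homo sapiens) for cytotoxicity, read by luminescence and CellTiter-Glo, with a stated time of 3 days (on this read-out higher numbers stand for weaker inhibition and lower numbers for stronger inhibition), compound 1 (`N#Cc1ccc(NC(=O)c2ccc(F)cc2O)cc1`) gives 3150 nM and compound 2 (`N#Cc1ccc(NC(=O)c2ccc(Br)cc2O)cc1`) gives 1450 nM, the lower of the two numbers so far. Compound 3 (`N#Cc1ccc(NC(=O)c2ccc(-c3ccncc3)cc2O)cc1`) carries pyridin-4-yl in place of bromo on an aromatic carbon. Within the data shown here, the only measured step at this place is a 2.2-fold lower number from compound 1 to compound 2 (0.34 log units; beyond the scatter), which is modest. Among the measured compounds shown here, no measured step brings in a ring, so that step gives only weak guidance. A modest further move towards a lower number is expected in this assay, with wide uncertainty. The estimated change is a 2.4-fold lower number from compound 2 to compound 3 (0.38 log units; beyond the scatter). For compound 3 the expected value is 600 nM, with an estimated range of 100 nM to 3500 nM.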

Compound 3, half-maximal inhibitory concentration: 8840 nM
Beside the measured number, compound 3's estimate is 15-fold (1.17 log units) below it; the whole stated range lies below it.
By their numbers in this assay, from the lowest: compound 2; then compound 1; then compound 3.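

In this assay, pyridin-4-yl in place of bromo gives a 6.1-fold higher number from compound 2 to compound 3 (0.79 log units; beyond the scatter), and pyridin-4-yl in place of fluoro gives a 2.8-fold higher number from compound 1 to compound 3 (0.45 log units; beyond the scatter). This position therefore does not follow one direction: the lower number seen on going from fluoro to bromo does not carry over to this ring, which stands above both halogens. No data at hand give a reason for the rise. Still open, on these data alone, is whether the ring or its nitrogen sets this number. A plain phenyl ring or an amine at this place would address that.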